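Carbonyl substituent exchanges in a low-inhibition furyl series

The source may hold more compounds than are shown below. What is called first, only, known or untested is meant among the compounds shown, and "the series" means these compounds.

All three measured compounds share one core and differ only in the group on a carbonyl carbon. Compound 1 `COC(=O)C1=C(C)NC(=O)NC1c1ccoc1` gives 8% in an assay on membranes from CHO cells for displacement of a labelled ligand from adenosine receptor A1 (Homo sapiens), read by scintillation counting, with a stated time of 60 min, tested at 1 uM; on this read-out higher numbers stand for more inhibition at the one concentration tested (going by the name of the read-out) and lower numbers for less inhibition. Compound 2 `CC1=C(C(=O)C2CC2)C(c2ccoc2)NC(=O)N1` gives 1% in this assay, and compound 3 `CCNC(=O)C1=C(C)NC(=O)NC1c1ccoc1` gives 1% in this assay. The steps of a number 7 percentage points lower from compound 1 to compound 2 (within the scatter) and a number 7 percentage points lower from compound 1 to compound 3 (within the scatter) are within the scatter, as is no change at the digits printed from compound 2 to compound 3 (within the scatter). Compound 3 therefore stands level with compound 2 at the digits shown, and both lie within the scatter of compound 1; no compound in the set separates from the others.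

Compound 4 `CC1=C(C(=O)SC(C)C)C(c2ccoc2)NC(=O)N1` is to be measured in this assay. The change is isopropylsulfanyl in place of ethylamino on a carbonyl carbon. Among the compounds with values here, the steps that bear on it are the three exchanges already made on the same carbonyl carbon, none of which moved the read-out beyond the scatter. Expected is therefore a number 2 percentage points higher from compound 3 to compound 4 (within the scatter), none beyond the scatter. Compound 4 is expected to give 3%, with a range from -6% to 15%.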

Compound 4, a percentage reported as inhibition, at one concentration (the size of the read-out at that concentration, not a potency): 9%
For compound 4 the middle estimate is 6 percentage points below the measured one, and the stated range covers the measured number.
By their numbers in this assay, from the lowest: compounds 2, 3, 1 and 4 (each within the scatter of the next).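

In this assay, within the data shown here, the isopropylsulfanyl group is the first on this carbonyl carbon to be joined through sulfur, yet its steps all remain within the scatter (a number 8 percentage points higher from compound 3 to compound 4 (within the scatter); a number 8 percentage points higher from compound 2 to compound 4 (within the scatter); a number 1 percentage points higher from compound 1 to compound 4 (within the scatter)). Groups joined through oxygen, carbon, nitrogen and sulfur therefore cannot be told apart here, and exchanging ethylamino, with its hydrogen-bond donor, for isopropylsulfanyl, with none, gives no step beyond the scatter. No available evidence bears on this result.

From the compounds shown here alone, whether a carboxylic acid, a dimethylamino group or a longer alkyl chain on this carbonyl carbon would separate from the four compounds remains open. With only one concentration tested, any difference in potency among these compounds also remains open.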